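A cyano group added to compound 3

A few compounds are considered here, and "the series" means these few. Any claim that something is new, unique, unknown or untested is made for them only; others in the source may bear on it.

Measured so far in a physicochemical assay for solubility; on this read-out lower numbers stand for lower solubility and higher numbers for higher solubility:
compound 1 `CS(=O)(=O)c1ccc(-n2nc(C(F)(F)F)c(C#N)c2-c2ccccc2)nc1` reads 100 ug/mL
compound 2 `CS(=O)(=O)c1ccc(-n2nc(C(F)(F)F)c(C#N)c2NC2CCC2)nc1` reads "not determined" (no result reported)
compound 3 `CC(C)(C)CNc1cc(C(F)(F)F)nn1-c1ccc(S(C)(=O)=O)cn1` reads "not determined" (no result reported)

For the measured compounds named here, compound 3 has no single number to stand on, and compound 2 is in the same position, so compound 1 alone carries a figure in this assay so far. Compound 4 `CC(C)(C)CNc1c(C#N)c(C(F)(F)F)nn1-c1ccc(S(C)(=O)=O)cn1` has yet to be measured. The change leading to it is cyano in place of hydrogen on an aromatic carbon and in words it is cyano in place of hydrogen on an aromatic carbon, next to the ring atom that bears a neopentylamino group and next to the ring atom that bears a trifluoromethyl group.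

Going by the values given here, with no number for compound 3, no measured step anchors this change. In this assay no step beyond the usual scatter is expected, in either direction, although the missing starting value means this expectation cannot be checked. Among the compounds with values here, the one reference is compound 1, which also carries the cyano and trifluoromethyl groups and reads 100 ug/mL in this measurement, but it has a different group where compound 4 bears neopentylamino. For compound 4 the expected value is 40 ug/mL with an estimated range from 8 ug/mL to 150 ug/mL in this measurement.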

Compound 4, solubility: < 25 ug/mL
Compound 4 gave a limit, no number; the forecaster's own chance of this, stated with the estimate: 15%; at least 1.6-fold (0.20 log units) between middle value and limit.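

Compound 4 is held only by a limit in this assay, not by a number: the limit of < 25 ug/mL in this assay, at which 1 of the 4 values shown sits.

Even so, that limit gives this set its first step that can be read: with the cyano and trifluoromethyl groups shared, neopentylamino in place of phenyl on an aromatic carbon gives an at least 4.0-fold lower number from compound 1 to compound 4 (0.60 log units; beyond the scatter), so the group on the ring atom that bears the neopentylamino group in compound 4 shifts this read-out by more than repeat measurements would. As far as these compounds go, the step from compound 3 to compound 4 cannot be read, as compound 3 has no single number, and the size of cyano in place of hydrogen on this aromatic carbon therefore stays unknown.

From the compounds shown here alone, how far compound 4 lies under its limit remains open, and so does any ranking of compound 2, which gives no result in this assay. Also open, going by these compounds, is how a carboxylic acid or a primary amine in place of neopentylamino would read in this assay with the cyano group kept.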